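Trifluoromethyl for methoxy in a compound at the limit

The source may hold more compounds than are shown below. What is called first, only, known or untested is meant among the compounds shown, and "the series" means these compounds.

In a functional assay on KB cells (Homo sapiens) for inhibition (on this read-out higher numbers stand for weaker inhibition and lower numbers for stronger inhibition), compound 1 (`COc1ccc(Cn2c(N)nc3cc(Cl)c(Cl)cc32)cc1`) gives 45000 nM. Compound 2 (`COc1ccc(Cn2c(Cl)nc3cc(Cl)c(Cl)cc32)cc1`) reads > 100000 nM, which is a limit of the assay and not a number. Compound 3 (`Clc1ccc(Cn2c(Cl)nc3cc(Cl)c(Cl)cc32)cc1Cl`) reads > 100000 nM, which is also a limit. Compound 2 therefore stands at the limit of > 100000 nM in this assay, at which 2 of the 3 values shown sit.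

Compound 4 (`FC(F)(F)c1ccc(Cn2c(Cl)nc3cc(Cl)c(Cl)cc32)cc1`) carries trifluoromethyl in place of methoxy on an aromatic carbon, para to a large group: trifluoromethyl in place of methoxy on an aromatic carbon. Among the compounds with values here, only one measured step is available, an at least 2.2-fold higher number from compound 1 to compound 2 (0.34 log units; beyond the scatter). That step, chloro in place of amino on an aromatic carbon, leaves the methoxy untouched, so it bears on the new change only indirectly. It does show that compound 2 has lost the measurable inhibition seen with compound 1. Compound 3 also lacks the methoxy, yet it gives only a limit, so it offers no number for a change at that group. With no sign of a gain, compound 4 is expected to stay at or near the limit, with no change beyond the scatter. The expected step is a number no higher from compound 2 to compound 4 (the limit leaves the size open). For compound 4 the estimate is 100000 nM, with an expected range from 50000 nM to 200000 nM.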

Compound 4, half-maximal inhibitory concentration: > 100000 nM
Compound 4: a limit, no number; the forecaster's own chance of this, stated with the estimate: 75%; the middle value lies on the limit itself.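

In this assay compound 4 reads > 100000 nM, which is a limit of the assay and not a number. Compound 2 also gives only a limit, so the step from compound 2 to compound 4 cannot be read. Compound 4 stands with the other compounds at that limit: the limit of > 100000 nM in this assay, at which 3 of the 4 values shown sit.

The compounds shown leave open whether trifluoromethyl in place of methoxy changes inhibition on this read-out at all.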